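The compounds below may be only part of what the source reports. "The series", "measured", "known", "first", "only" and "open" are said of these compounds alone.

Working notes on the series.

Compound 1 `CC(C)CCCN(C)Cc1ccc(C2=CCCN(C)C2)cc1` is the starting point. In an ADME assay on HL-60 cells (Homo sapiens) for cytotoxicity, read by MTT assay, with a stated time of 24 h (a higher number here means a weaker inhibitor, a lower number a stronger inhibitor), compound 1 gives > 50000 nM, which is a limit of the assay and not a number. Compound 2 `CN1CCC=C(c2ccc(CN(C)Cc3ccc(Cl)cc3)cc2)C1` differs from compound 1 by 4-chlorophenyl in place of isopentyl on a saturated chain carbon bound to an amine nitrogen. In this assay compound 2 gives > 50000 nM, again only a limit. The step from compound 1 to compound 2 is therefore a step that the two limits leave unreadable from compound 1 to compound 2. Compound 3 `CC(C)CCCN(C)Cc1ccc(C2CCCN(C)C2)cc1` carries the other core; it differs from compound 1 by a group of 7 heavy atoms (6 carbon, 1 nitrogen; one six-membered non-aromatic ring with 1 hetero atom) in place of a group of 7 heavy atoms (6 carbon, 1 nitrogen; one six-membered non-aromatic ring with 1 hetero atom), on an aromatic carbon. In this assay compound 3 gives > 50000 nM, once more a limit. The step between the cores, from compound 1 to compound 3, is a step that the two limits leave unreadable from compound 1 to compound 3. Taken together, (the limit of > 50000 nM in this assay, at which 3 of the 3 values shown sit); no step size can be read anywhere in the measured set.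

Compound 4 `CN(Cc1ccc(Cl)cc1)Cc1ccc(C2CCCN(C)C2)cc1` is not yet measured. From compound 3 it is reached by 4-chlorophenyl in place of isopentyl on a saturated chain carbon bound to an amine nitrogen. This is the same change as from compound 1 to compound 2, and the place is described in identical words for both pairs, so it is the same change on the second core. The step from compound 3 to compound 4 in this assay is expected to be a step that the limit leaves unreadable from compound 3 to compound 4, resting on (the limit of > 50000 nM in this assay, at which 3 of the 3 values shown sit), which leaves no sign that either change moves a compound off the limit. Compound 4 is expected at 80000 nM, within 40000 nM to 200000 nM, and most likely reported only as a limit.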

Compound 4, half-maximal inhibitory concentration: > 50000 nM
Compound 4: a limit, no number; the forecaster's own chance of this, stated with the estimate: 85%; the middle value lies beyond the limit too.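

In this assay compound 4 gives > 50000 nM as a limit and not a number. No new step can be read, neither from compound 3 to compound 4 nor from compound 2 to compound 4, and the series stays at a single limit: the limit of > 50000 nM in this assay, at which 4 of the 4 values shown sit.

Whether the change from isopentyl to 4-chlorophenyl or the change of core alters cytotoxicity at all in this assay stays open for the compounds shown.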